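Amide side-chain exchange from compound 1 to compound 4

The compounds below may be only part of what the source reports. "The series", "measured", "known", "first", "only" and "open" are said of these compounds alone.

Measured compounds:
compound 1 `CN(C)C(=O)CNC(=O)c1cn(Cc2ccc(-n3cccn3)cc2)c2cccnc12` — 9.3 mL/min/kg
compound 2 `Cn1ccc(-c2ccc(Cn3cc(C(=O)N[C@H]4CCOC[C@@H]4O)c4ncccc43)cc2)n1` — 10.6 mL/min/kg
compound 3 `Cc1ccnc2c(C(=O)N[C@H]3CCOC[C@@H]3O)cn(Cc3ccc(-c4ccn(C)n4)cc3)c12` — 10.6 mL/min/kg

In an ADME assay on liver for metabolic stability, with Liver microsome (Homo sapiens) as the target, using microsomes (a lower number here means slower removal, a higher number faster removal of the compound), compound 1 gives 9.3 mL/min/kg, while compound 2 gives 10.6 mL/min/kg and compound 3 gives 10.6 mL/min/kg. All three numbers lie within the usual scatter of one another, so compound 1 is not set apart from compound 2 or compound 3 on this read-out.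

Compound 4 `O=C(N[C@H]1CC[C@H](CO)CC1)c1cn(Cc2ccc(-n3cccn3)cc2)c2cccnc12` is not yet measured. It differs from compound 1 in one place: 4-(hydroxymethyl)cyclohexyl in place of (dimethylcarbamoyl)methyl on an amide-type nitrogen.

Going by the values given here, the only step measured is no change at the digits printed from compound 2 to compound 3 (within the scatter), which concerns a methyl on an aromatic carbon and not the amide nitrogen; it says nothing direct about the exchange in hand. Among the compounds with values here, no measured pair changes the group on the amide nitrogen, so there is no internal precedent for the size of the step. Given that the three measured numbers cluster closely, a step of at most modest size in this assay is expected, with the direction left open; the estimated step is a 1.3-fold higher number from compound 1 to compound 4 (0.11 log units; within the scatter). For compound 4 the expected value in this assay is 12 mL/min/kg, with a range from 6 mL/min/kg to 25 mL/min/kg.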

Compound 4, clearance: 8.5 mL/min/kg
Beside the measured number, compound 4's estimate is 1.4-fold (0.15 log units) above it; the range from low to high includes it.
By their numbers in this assay, from the lowest: compounds 4, 1, 2 and 3 (each within the scatter of the next).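

In this assay, the group on the amide-type nitrogen now has one measured exchange: 4-(hydroxymethyl)cyclohexyl in place of (dimethylcarbamoyl)methyl gives a 1.1-fold lower number from compound 1 to compound 4 (0.04 log units; within the scatter). Going by these compounds alone, the earlier compounds held no pair that varied this position, so this is the first direct reading of it, and it shows that the read-out does not separate the two groups. The entering group differs substantially from the one it replaces, with a six-membered non-aromatic ring of carbon only, a hydrogen-bond donor and two defined stereocentres against a chain with no ring and no donor, yet no evidence available here bears on why the two compounds are not set apart.

A single pair within the scatter leaves open whether any group on this nitrogen can set a compound apart in this assay, and a plain cyclohexyl, a cyclohexyl bearing a carboxylic acid or an amine in place of the hydroxymethyl, or a longer chain would each test this on the core of compound 1. From the compounds shown here alone, the other stereoisomer of the 4-(hydroxymethyl)cyclohexyl group also remains open, so the role of its two defined stereocentres on this read-out cannot be judged.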